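This account rests on a few compounds, and the source may have more. Where it says the series, first, only, none or still open, it means among the compounds named here.

Within the data shown here, in a physicochemical assay for lipophilicity, read by mass spectrometry (a lower number here means a more polar compound, a higher number a more lipophilic compound), two compounds sharing one core have numbers so far. Compound 1 (`COc1ccc(NC(=O)C2Cc3cc(OC)c(OC)cc3C2=O)cc1`) gives 2.08 and compound 2 (`COc1cc2c(cc1OC)C(=O)C(C(=O)Nc1ccc(Br)cc1)C2`) gives 3.03 as the higher of the two. Compound 3 (`COc1cccc(NC(=O)C2Cc3cc(OC)c(OC)cc3C2=O)c1`) has not been measured yet. It differs from compound 2 by 3-methoxyphenyl in place of 4-bromophenyl on an amide-type nitrogen. Among the measured compounds shown here, one measured step bears on this, bromo in place of methoxy on an aromatic carbon, which gave a number 0.95 log units higher from compound 1 to compound 2 (beyond the scatter) in a single change. The move to compound 3 trades bromo for methoxy in the opposite sense, so a fall of similar size in this assay is expected, with compound 1 at 2.08 as the nearest guide. For the measured compounds named here, compound 3 does not carry quite the same group as compound 1, however, and no measured pair shows what moving the methoxy group does. The expected change is a number 0.88 log units lower from compound 2 to compound 3 (beyond the scatter) and no finer figure can be supported. For compound 3 the estimate is 2.15 with 1.8 to 2.5 as its expected range.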

Compound 3, partition coefficient: 2.08
The estimate for compound 3 lay 0.07 log units above the measured number; low and high end bracket the measured number.
By their numbers in this assay, from the lowest: compounds 1 and 3 (each within the scatter of the next); then compound 2.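

In this assay, putting 3-methoxyphenyl in place of 4-bromophenyl on the amide-type nitrogen gives a number 0.95 log units lower from compound 2 to compound 3 (beyond the scatter) and so extends the earlier bromo-to-methoxy comparison to a second methoxyphenyl group. The new pair also gives the first direct look at the two methoxyphenyl groups: 3-methoxyphenyl in place of 4-methoxyphenyl gives no change at the digits printed from compound 1 to compound 3 (within the scatter) and leaves these two compounds indistinguishable in this measurement, so among the compounds shown the number tracks whether the group on the nitrogen is 4-bromophenyl or a methoxyphenyl, not which of the two methoxyphenyl groups is present. No measurement shown here offers an explanation for either step.

With only three compounds, all sharing one core and differing only in the aromatic group on that nitrogen, this is a small set of comparisons, and it does not show whether the same agreement would hold for other pairs of groups on the ring. It also leaves open how the number would respond to an amine or a carboxylic acid on the phenyl ring, or to a longer chain on the nitrogen in place of the aromatic group.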